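Chloro on the Core of Compound 1

The compounds below may be only part of what the source reports. "The series", "measured", "known", "first", "only" and "open" are said of these compounds alone.

compound 1, `C#CCn1cc(C(=O)NC(CC(=O)Nc2ccccc2)c2ccccc2)c(=O)c2cccnc21`: > 10000 nM
compound 2, `C#CCn1cc(C(=O)NC(CC(=O)NC2CCCC2)c2ccccc2)c(=O)c2cc(F)c(Cl)nc21`: 2100 nM
compound 3, `C#CCn1cc(C(=O)NC(CC(=O)Nc2ccccn2)c2ccccc2)c(=O)c2cc(F)c(Cl)nc21`: 2300 nM

In a functional assay on SW-620 cells (Homo sapiens) for cytotoxicity, read by MTT assay, with a stated time of 72 h (a lower number here means a stronger inhibitor, a higher number a weaker inhibitor), compound 1 gives > 10000 nM, which is a limit of the assay and not a number, the point where (the limit of > 10000 nM in this assay, at which 1 of the 3 values shown sits). Compound 2 gives 2100 nM and compound 3 gives 2300 nM. Among the measured compounds shown here, the only measured step, a 1.1-fold higher number from compound 2 to compound 3 (0.04 log units; within the scatter), concerns the amide-type nitrogen and says nothing about the core. Compound 4, `C#CCn1cc(C(=O)NC(CC(=O)Nc2ccccc2)c2ccccc2)c(=O)c2ccc(Cl)nc21`, differs from compound 1 by chloro in place of hydrogen on an aromatic carbon. For the measured compounds named here, no measured step covers a change of this kind, so the expectation rests on the limit of compound 1 alone and stays wide. Compound 4 is expected to give 6000 nM, within 2000 nM to 20000 nM. The expected step is an at least 1.6-fold lower number from compound 1 to compound 4 (0.22 log units; that floor lies within the scatter).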

Compound 4, half-maximal inhibitory concentration: 2900 nM
Compound 4: the middle estimate sits 2.1-fold (0.32 log units) above what was measured, within the range that was stated.
By their numbers in this assay, from the lowest: compounds 2, 3 and 4 (each within the scatter of the next). At a limit, above all of these: compound 1.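

In this assay, chloro in place of hydrogen on an aromatic carbon next to the ring nitrogen gives an at least 3.4-fold lower number from compound 1 to compound 4 (0.53 log units; beyond the scatter), which shows that this position can move the number beyond the scatter. The value of compound 1 is a limit, so the step is only a floor and its full size remains unknown: the limit of > 10000 nM in this assay, at which 1 of the 4 values shown sits.

The compounds shown leave open whether only chloro does this at this position, or whether methyl, methoxy or an amine there would give a similar number.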